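The source may report more compounds than this note shows. Statements on the series, on what has been measured and on what is new or still open speak of the compounds shown alone.

Compound 1 (`COc1cc(C2Oc3cc(-c4oc5cc(O)cc(O)c5c(=O)c4OC)ccc3OC2CO)ccc1O`) was tested in a functional assay on HUVEC cells (Homo sapiens) for inhibition, read by microscopy and crystal violet staining, with a stated time of 20 h (on this read-out higher numbers stand for weaker inhibition and lower numbers for stronger inhibition), where compound 1 gives 11300 nM. Two relatives were read in the same way. Compound 2 (`COc1cc(C2Oc3cc(-c4oc5cc(O)cc(O)c5c(=O)c4O)ccc3OC2CO)ccc1OC(=O)c1cc(O)c(O)c(O)c1`) gives 8200 nM, which lies within the usual scatter of the value for compound 1. Compound 3 (`COc1cc(C2Oc3cc(-c4oc5cc(OC(=O)c6cc(O)c(O)c(O)c6)cc(O)c5c(=O)c4O)ccc3OC2CO)ccc1O`) gives 4700 nM, a lower number than that of compound 1 and beyond the scatter from it. All three numbers therefore sit in a fairly narrow band.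

Compound 4 (`COc1cc(O)c2c(=O)c(OC)c(-c3ccc4c(c3)OC(c3ccc(O)c(OC)c3)C(CO)O4)oc2c1`) departs from compound 1 by one small change: methyl in place of hydrogen on an oxygen on an aromatic ring, or hydroxy to methoxy. Among the compounds with values here, no measured pair in this set isolates that change, so the data offer no direct guide to its size or direction. The expectation is therefore a modest one, with no shift beyond the scatter in this assay. The step of a 1.1-fold higher number from compound 1 to compound 4 (0.03 log units; within the scatter) is expected to be small. For compound 4 the estimated value is 12000 nM, with an expected range from 6000 nM to 25000 nM.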

Compound 4, half-maximal inhibitory concentration: 49900 nM
Compound 4: the middle estimate sits 4.2-fold (0.62 log units) below what was measured; the measured number lies above the stated range.
By their numbers in this assay, from the lowest: compounds 3, 2 and 1 (each within the scatter of the next, the first and the last beyond it); then compound 4.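

In this assay, methyl in place of hydrogen on an oxygen on an aromatic ring is not a neutral change at this position: going from hydroxy to methoxy gives a 4.4-fold higher number from compound 1 to compound 4 (0.65 log units; beyond the scatter) and so weakens inhibition. Within the data shown here, this is the first step in the set that isolates a single change, and it shows that even one added carbon at this oxygen can move the read-out beyond the usual scatter. No supporting measurement explains the size of this step.

The compounds shown leave open whether a longer chain on this oxygen, such as ethyl, or a carboxylic acid carried on such a chain, would weaken inhibition further. They also leave open whether the same hydroxy to methoxy change would have a similar effect on the other aromatic hydroxy groups of the shared core.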